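The compounds below may be only part of what the source reports. "The series", "measured", "known", "first", "only" and "open" are said of these compounds alone.

Two compounds of this series have numbers in a functional assay on DLD-1 cells (Homo sapiens) for cytotoxicity, read by MTT assay, with a stated time of 48 h; on this read-out higher numbers stand for weaker inhibition and lower numbers for stronger inhibition. Compound 1 `CN(C)CCNc1ccnc2cc(OCc3ccccc3)ccc12` gives 2140 nM in this assay. Compound 2 `CCCCCCOc1ccc2c(Cl)ccnc2c1` gives 2660 nM in this assay. Compound 2 holds the highest of the two numbers; its nearest neighbour is compound 1, whose number is lower by an amount within the scatter, so no order between the two can be read. Going by the values given here, no pair of measured compounds differs in only one place, so the weight of any single change cannot be taken from the numbers at hand.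

Compound 3 `Clc1ccnc2cc(OCc3ccccc3)ccc12` is not yet measured. It differs from compound 2 in one place: phenyl in place of pentyl on a saturated chain carbon bound to an oxygen on an aromatic ring. Without a measured step of this kind, the step in this assay is expected to be none beyond the scatter, a 1.1-fold lower number from compound 2 to compound 3 (0.04 log units; within the scatter). Compound 1, which also carries the phenyl group, gives 2140 nM and sits close to compound 2. Compound 3 is therefore estimated at 2400 nM in this assay, with a range from 800 nM to 7500 nM.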

Compound 3, half-maximal inhibitory concentration: 3270 nM
Beside the measured number, compound 3's estimate is 1.4-fold (0.13 log units) below it; the measured number falls inside the stated range.
By their numbers in this assay, from the lowest: compounds 1, 2 and 3 (each within the scatter of the next).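

In this assay the change at the saturated chain carbon bound to an oxygen on an aromatic ring now has a measured size: phenyl in place of pentyl gives a 1.2-fold higher number from compound 2 to compound 3 (0.09 log units; within the scatter) and so does not separate the aromatic ring from the open chain at this place. Compound 3 also supplies a second one-place comparison, since chloro in place of (2-(dimethylamino)ethyl)amino on an aromatic carbon gives a 1.5-fold higher number from compound 1 to compound 3 (0.18 log units; within the scatter) and this exchange, too, stays inside the scatter. No measurement beyond these numbers bears on the result.

The compounds shown leave open whether a group other than pentyl or phenyl, such as a longer chain or a pyridyl ring, would move the number beyond the scatter at the chain carbon, and whether a primary amine or a carboxylic acid would do so on the aromatic carbon. They also leave open whether the phenyl for pentyl step keeps its size when (2-(dimethylamino)ethyl)amino rather than chloro stands on the aromatic carbon.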